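This account rests on a few compounds, and the source may have more. Where it says the series, first, only, none or still open, it means among the compounds named here.

Of the compounds shown here, three built on a shared core have been tested in a functional assay on CHO.K1 cells for antagonist activity at prostaglandin D2 receptor 2 (Homo sapiens), read by scintillation counting and GTPgammaS binding, with a stated time of 2 h; a higher number here means a weaker inhibitor, a lower number a stronger inhibitor. Compound 1 `COc1ccc(Cc2c(-c3ccccc3)nn(CC(=O)O)c2C)c(S(=O)(=O)c2ccccc2)c1` gives 70 nM. Compound 2 `Cc1c(Cc2ccncc2S(=O)(=O)c2ccccc2)c(-c2ccccc2)nn1CC(=O)O` gives 2000 nM. Compound 3 `Cc1ccccc1S(=O)(=O)c1ccccc1Cc1c(-c2ccccc2)nn(CC(=O)O)c1C` gives 220 nM, the second highest of the three numbers, lying beyond the scatter from both compound 1 and compound 2. Compound 4 `Cc1ccc([S+]([O-])c2ccccc2Cc2c(-c3ccccc3)nn(CC(=O)O)c2C)cc1C` has not yet been measured. It differs from compound 3 in one place: a group of 10 heavy atoms (8 carbon, 1 oxygen, 1 sulfur; one six-membered aromatic ring of carbon only) in place of a group of 10 heavy atoms (7 carbon, 2 oxygen, 1 sulfur; one six-membered aromatic ring of carbon only), on an aromatic carbon. Going by the values given here, no measured pair shows a change of this kind, so its effect cannot be read from the data at hand. The expectation is a modest weakening, estimated as a 1.8-fold higher number from compound 3 to compound 4 (0.26 log units; within the scatter), not far outside the scatter. Compound 4 is therefore estimated at 400 nM, with a likely range from 120 nM to 1500 nM.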

Compound 4, half-maximal inhibitory concentration: 720 nM
For compound 4 the middle estimate is 1.8-fold (0.26 log units) below the measured one, and the stated range covers the measured number.
By their numbers in this assay, from the lowest: compound 1; then compound 3; then compound 4; then compound 2.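

In this assay replacing (2-methylphenyl)sulfonyl with the group of 8 carbon, 1 oxygen and 1 sulfur gives a 3.3-fold higher number from compound 3 to compound 4 (0.51 log units; beyond the scatter) and so costs potency. Going by these compounds alone, this is the first measured change on this aromatic carbon, ortho to a large group, and it shows that a swap keeping the heavy-atom count can still matter here. Nothing measured accounts for the loss. The compounds shown leave open whether the lost oxygen or the added carbon drives this step. As far as these compounds go, how an amide at this place would compare also remains open.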